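Side chain growth from compound 3 to compound 4

The compounds below may be only part of what the source reports. "The series", "measured", "known", "first", "only" and "open" are said of these compounds alone.

Measured in a functional assay on PANC-1 cells (Homo sapiens) for inhibition, read by MTT assay, with a stated time of 72 h; a lower number here means a stronger inhibitor, a higher number a weaker inhibitor:
- compound 1 `Cc1cnc(C(=O)Nc2cc(Cl)cc3cccnc23)cn1`: 1770 nM
- compound 2 `COc1cc(NC(=O)c2cnc(C)cn2)c2ncccc2c1`: 800 nM
- compound 3 `Cc1cnc(C(=O)Nc2cc(OCCN)cc3cccnc23)cn1`: > 10000 nM, a limit and not a number

Compound 3 has no number to stand on, only (the limit of > 10000 nM in this assay, at which 1 of the 3 values shown sits). Compound 4 `Cc1cnc(C(=O)Nc2cc(OCCC3CCNCC3)cc3cccnc23)cn1` has piperidin-4-yl in place of amino on a saturated chain carbon, two bonds along the chain from an oxygen on an aromatic ring. Going by the values given here, the steps that bear on this are an at least 5.6-fold higher number from compound 1 to compound 3 (0.75 log units; beyond the scatter) and an at least 12-fold higher number from compound 2 to compound 3 (1.09 log units; beyond the scatter), modest and large, both towards a higher number. Neither tests a larger amine-bearing group, so only a modest step towards a lower number is expected in this assay. The expected step is an at least 2.0-fold lower number from compound 3 to compound 4 (0.30 log units; that floor lies within the scatter). The estimate for compound 4 is 5000 nM, with a range of 1500 nM to 15000 nM.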

Compound 4, half-maximal inhibitory concentration: > 10000 nM
Compound 4 was reported as a limit; the forecaster's own chance of this, stated with the estimate: 30%; middle value at least 2.0-fold (0.30 log units) from the limit.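

In this assay compound 4 gives > 10000 nM, a limit and not a number, so the step from compound 3 cannot be read. Against the chloro and methoxy groups, 2-(piperidin-4-yl)ethoxy gives an at least 12-fold higher number from compound 2 to compound 4 (1.09 log units; beyond the scatter) and an at least 5.6-fold higher number from compound 1 to compound 4 (0.75 log units; beyond the scatter). Replacing amino with the larger piperidin-4-yl therefore does not bring a readable value at this place, and the series stays at the same limit: the limit of > 10000 nM in this assay, at which 2 of the 4 values shown sit.

Left open is whether 2-hydroxyethoxy, or a chain ending in a carboxylic acid rather than an amine, would give a readable value here. On these data alone, how compound 3 and compound 4 rank against each other also stays open.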